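The source may hold more compounds than are shown below. What is called first, only, known or untested is meant among the compounds shown, and "the series" means these compounds.

In a functional assay on RS4-11 cells (Homo sapiens) for inhibition, read by CCK-8 assay, with a stated time of 48 h (on this read-out lower numbers stand for stronger inhibition and higher numbers for weaker inhibition), compound 1 `O=C(NCCNS(=O)(=O)c1ccc(-c2ccccc2OCc2cccc(O)c2)s1)Nc1cc(Cl)cc(Cl)c1` reaches only a limit of the assay, > 50000 nM. Compound 2 `O=[N+]([O-])c1cccc(NC(=S)NCCNS(=O)(=O)c2ccc(-c3ccccc3OCc3ccccc3)s2)c1` gives 11600 nM and compound 3 `O=[N+]([O-])c1ccc(NC(=S)NCCNS(=O)(=O)c2ccc(-c3ccccc3OCc3cccc(O)c3)s2)cc1` gives 10100 nM, two values within the scatter of each other. Going by the values given here, compound 3 therefore stands level with compound 2, and these are the only two actual numbers in the set.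

Compound 4 `O=[N+]([O-])c1cccc(NC(=S)NCCNS(=O)(=O)c2ccc(-c3ccccc3OCc3cccc(O)c3)s2)c1` has the same atoms as compound 3, joined differently: 3-nitrophenyl in place of 4-nitrophenyl on an amide-type nitrogen. In words, 3-nitrophenyl sits in place of 4-nitrophenyl on an amide-type nitrogen. Among the compounds with values here, only one measured step touches this site, an at least 4.9-fold lower number from compound 1 to compound 3 (0.69 log units; beyond the scatter). That step exchanges a different and larger group and starts from a limit, so it shows that the site can matter but says little about moving a nitro group within the ring. The closer guide is compound 2, which already carries the 3-nitrophenyl group and gives 11600 nM, although it also differs from compound 4 elsewhere. No step beyond the scatter is therefore expected, and the estimated change is a 1.0-fold lower number from compound 3 to compound 4 (0.00 log units; within the scatter). Compound 4 is expected to give about 10000 nM, with an estimated range of 5000 nM to 21000 nM.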

Compound 4, half-maximal inhibitory concentration: 9800 nM
Beside the measured number, compound 4's estimate is 1.0-fold (0.01 log units) above it; the measured number falls inside the stated range.
By their numbers in this assay, from the lowest: compounds 4, 3 and 2 (each within the scatter of the next). At a limit, above all of these: compound 1.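

In this assay, 3-nitrophenyl and 4-nitrophenyl on the amide-type nitrogen cannot be told apart, with a 1.0-fold lower number from compound 3 to compound 4 (0.01 log units; within the scatter), so the place of the nitro group on this ring makes no difference that can be read between these two compounds. Hydroxy in place of hydrogen on an aromatic carbon, a change no earlier pair isolated, also stays within the scatter, with a 1.2-fold lower number from compound 2 to compound 4 (0.07 log units; within the scatter). The exchange of the whole group on the amine nitrogen gives an at least 5.1-fold lower number from compound 1 to compound 4 (0.70 log units; beyond the scatter), which agrees with the earlier step from that compound but starts from a limit and not from a number: the limit of > 50000 nM in this assay, at which 1 of the 4 values shown sits.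

The compounds shown leave open whether an amine or a carboxylic acid in place of the nitro group would give a value beyond the scatter of these three. They also leave open which part of the exchange from compound 1 matters, the thiocarbonyl in place of the carbonyl or the nitro group in place of the two chlorine atoms, as the two always change together here.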